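The compounds below may be only part of what the source reports. "The series", "measured", "known", "first", "only" and "open" are said of these compounds alone.

Measured so far in a functional assay on MGC-803 cells (Homo sapiens) for inhibition, read by MTT assay, with a stated time of 48 h; a higher number here means a weaker inhibitor, a lower number a stronger inhibitor:
- compound 1 `COc1ccc(-c2coc3cc(OCCCSC(=S)N4CCOCC4)ccc3c2=O)cc1`: 49600 nM
- compound 2 `COc1ccc(-c2coc3cc(OCCCSC(=S)N4CCN(C(C)=O)CC4)ccc3c2=O)cc1`: 39400 nM

Among the compounds with values here, compound 1 gives the highest of the two numbers; its nearest neighbour is compound 2, and the only step in hand, a 1.3-fold lower number from compound 1 to compound 2 (0.10 log units; within the scatter), concerns the amine on the thiocarbonyl carbon and lies within the scatter. Both measured compounds therefore sit at weak, closely similar inhibition.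

Compound 3 `COc1ccc(-c2coc3cc(OCCBr)ccc3c2=O)cc1` is the unmeasured member. Relative to compound 1 the change is one bromine atom in place of a group of 10 heavy atoms (6 carbon, 1 nitrogen, 1 oxygen, 2 sulfur; one six-membered non-aromatic ring with 2 hetero atoms), on a saturated chain carbon, two bonds along the chain from an oxygen on an aromatic ring. Within the data shown here, no measured step touches this change: the one step in hand swaps one amine for another on the thiocarbonyl carbon and does not remove that carbon or the chain beyond it. The expectation for compound 3 can thus rest only on the weak level shared by compound 1 and compound 2, with a wide range to allow either direction.

Compound 3 is expected to give about 60000 nM, a step of a 1.2-fold higher number from compound 1 to compound 3 (0.08 log units; within the scatter), within an estimated range of 20000 nM to 200000 nM.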

Compound 3, half-maximal inhibitory concentration: > 100000 nM
Compound 3: a limit, no number; the forecaster's own chance of this, stated with the estimate: 30%; at least 1.6-fold (0.22 log units) between middle value and limit.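

In this assay compound 3 gives a limit and no number: the limit of > 100000 nM in this assay, at which 1 of the 3 values shown sits.

Bromo on the saturated chain carbon, in place of the larger group with its six-membered non-aromatic ring, gives an at least 2.0-fold higher number from compound 1 to compound 3 (0.30 log units; that floor lies within the scatter). The change brings no sign of stronger inhibition at this position, but the floor of the step lies within the scatter, so a real loss on removing the group is not established.

Still open, from the compounds shown here alone, is whether any group at this position can bring the number well below the weak level shared by compound 1 and compound 2; a primary amine, a carboxylic acid or a longer chain ending in bromine would each test that. Also open, going by these compounds, is whether the thiocarbonyl carbon contributes anything apart from the amine it carries, which a simple amide in its place would address.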